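Replacing the Nitrile with an Aryl Ketone

The compounds below may be only part of what the source reports. "The series", "measured", "known", "first", "only" and "open" are said of these compounds alone.

Compound 3 `N#Cc1cc2c(-c3cccnc3)nn(-c3ccccc3)c2[nH]c1=O` gives 3.3 ug/mL in a functional assay on HepG2 cells (Homo sapiens) for cytotoxicity, read by sulforhodamine B assay (a higher number here means a weaker inhibitor, a lower number a stronger inhibitor), the lowest of the three numbers shown, although compound 2 `N#Cc1cc2c(-c3cccnc3)nn(-c3ccccc3)c2[nH]c1=S` with 3.9 ug/mL lies within the scatter of it. Compound 1 `O=C(c1ccc(Cl)cc1)c1cc2c(-c3cccnc3)nn(-c3ccccc3)c2[nH]c1=O` gives 9 ug/mL, beyond the scatter. Among the measured compounds shown here, the single step that bears on the question is a 2.7-fold lower number from compound 1 to compound 3 (0.44 log units; beyond the scatter). Compound 4 `Cc1ccc(C(=O)c2cc3c(-c4cccnc4)nn(-c4ccccc4)c3[nH]c2=O)cc1` differs from compound 3 by (4-methylphenyl)carbonyl in place of cyano on an aromatic carbon. That change closely resembles the reverse of the measured step, since once again a nitrile is exchanged for an aryl ketone on the same carbon, so a modest rise in the number is expected in this assay, roughly a 2.4-fold higher number from compound 3 to compound 4 (0.38 log units; beyond the scatter). Compound 4 is therefore estimated at 8 ug/mL, with a range from 4 ug/mL to 16 ug/mL.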

Compound 4, half-maximal inhibitory concentration: 8.85 ug/mL
Estimate against measurement, compound 4: 1.1-fold (0.04 log units) below; the measured number falls inside the stated range.
By their numbers in this assay, from the lowest: compounds 3 and 2 (each within the scatter of the next); then compounds 4 and 1 (each within the scatter of the next).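

In this assay, the step of a 2.7-fold higher number from compound 3 to compound 4 (0.43 log units; beyond the scatter) shows that the rise in the number seen with (4-chlorophenyl)carbonyl also appears with (4-methylphenyl)carbonyl, so on this aromatic carbon it is not confined to one aryl ketone. With methyl in place of chloro, the step is a 1.0-fold lower number from compound 1 to compound 4 (0.01 log units; within the scatter), so these two aryl ketones cannot be told apart here. Nothing available explains either step.

Still open, going by these compounds, is how a carboxylic acid or an amine on this carbon would compare with the nitrile. Also open, on these data alone, is where an aryl ketone carrying methoxy on its ring would fall.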